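The compounds below may be only part of what the source reports. "The series", "measured", "known", "first", "only" and "open" are said of these compounds alone.

The measured compounds, each with its number in a functional assay on HeLa cells (Homo sapiens) for antiproliferative activity, read by MTT assay, with a stated time of 48 h, in the presence of a further agent that is not named here; a lower number here means a stronger inhibitor of growth, a higher number a weaker inhibitor of growth:

Compound 1, `O=C(NOCc1ccccc1)c1cn(-c2ccccc2)nc1-c1ccccc1`: compound 1 gives 8830 nM.
Compound 2, `Cc1ccc(-c2nn(-c3ccccc3)cc2C(=O)NOCc2ccccc2)cc1`: compound 2 gives 6690 nM.
Compound 3, `Cc1ccc(-c2nn(-c3ccccc3)cc2C(=O)NOCc2ccccc2Cl)cc1`: compound 3 gives 4680 nM.

Compound 2 stands second highest of these three numbers in this assay, but the two steps that connect it to the others both lie within the scatter, so the three values cannot be placed in any order with confidence.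

Compound 4, `O=C(NOCc1ccccc1)c1cn(-c2ccccc2)nc1-c1ccc(Cl)cc1`, has not yet been measured. It differs from compound 2 in one place: chloro in place of methyl on an aromatic carbon. Two measured steps speak to this exchange. The first, a 1.3-fold lower number from compound 1 to compound 2 (0.12 log units; within the scatter), is the reverse of taking the methyl away at this very site and was within the scatter. The second, a 1.4-fold lower number from compound 2 to compound 3 (0.16 log units; within the scatter), brought a chloro onto a different aromatic carbon and was also within the scatter. Taking the methyl off and putting a chloro on thus combines two moves that each left the number essentially unchanged. For compound 4 no step beyond the scatter is therefore expected in this assay, and the expected step from compound 2 is a 1.0-fold lower number from compound 2 to compound 4 (0.01 log units; within the scatter). The estimate for compound 4 is 6500 nM, with a range from 3000 nM to 14000 nM.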

Compound 4, concentration for 50% growth inhibition: 8350 nM
For compound 4 the middle estimate is 1.3-fold (0.11 log units) below the measured one; the range from low to high includes it.
By their numbers in this assay, from the lowest: compounds 3, 2, 4 and 1 (each within the scatter of the next).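

On this aromatic carbon, the exchange of 4-methylphenyl to 4-chlorophenyl in this assay gives a 1.2-fold higher number from compound 2 to compound 4 (0.10 log units; within the scatter), and chloro in place of hydrogen gives a 1.1-fold lower number from compound 1 to compound 4 (0.02 log units; within the scatter). Hydrogen, methyl and chloro at this position therefore give numbers that cannot be told apart, whereas the earlier compounds offered that comparison only for hydrogen and methyl. Chloro in place of hydrogen can now also be compared at two different places, and the two results agree within the scatter: the same change on two cores in this assay, a 1.4-fold lower number (0.16 log units; within the scatter) from compound 2 to compound 3 and a 1.1-fold lower number (0.02 log units; within the scatter) from compound 1 to compound 4, 1.4-fold (0.13 log units) apart, within the scatter of two such steps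

Going by these compounds, what happens with a quite different group on this aromatic carbon stays open: an amine, a carboxylic acid or a longer chain might shift the number beyond the scatter or might leave it where it is, and these compounds give no way of telling which. No step among the compounds shown lies beyond the scatter, and the question of which part of the molecule, if any, can move the number in this assay also remains unanswered.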